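The source may hold more compounds than are shown below. What is called first, only, known or untested is meant among the compounds shown, and "the series" means these compounds.

Series notes. Compound 1 `CN1CC(=O)N/C1=N\C(=O)Nc1csc(Cl)c1` carries a chlorothiophene on the shared core and gives 434 nM in a functional assay for antagonist activity at metabotropic glutamate receptor 5 (Homo sapiens), read by FLIPR; on this read-out lower numbers stand for stronger inhibition and higher numbers for weaker inhibition. Compound 2 `CN1CC(=O)N/C1=N\C(=O)Nc1ccccc1` gives 3300 nM in this assay, and compound 3 `CN1CC(=O)N/C1=N\C(=O)Nc1ccccc1Cl` gives 6800 nM. The change hydrogen in place of chloro on an aromatic carbon produced a 2.1-fold lower number from compound 3 to compound 2 (0.31 log units; beyond the scatter). How the cores of compound 1 and compound 3 differ is not broken down here.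

Compound 4 `CN1CC(=O)N/C1=N\C(=O)Nc1ccsc1` is not yet measured. It arises from compound 1 by hydrogen in place of chloro on an aromatic carbon, the same kind of change as from compound 3 to compound 2, but on a five-membered aromatic ring with 1 sulfur, next to the ring sulfur and two ring bonds from the ring atom that bears a large group, rather than on a six-membered aromatic ring of carbon only, ortho to a large group. Because compound 2 gives 3300 nM against 434 nM for compound 1, loss of the chloro is expected to cost rather than gain, so a step of a 3.5-fold higher number from compound 1 to compound 4 (0.54 log units; beyond the scatter) is expected in this assay, a different direction from a 2.1-fold lower number from compound 3 to compound 2 (0.31 log units; beyond the scatter). The estimate for compound 4 is 1500 nM, expected between 400 nM and 6000 nM.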

Compound 4, half-maximal inhibitory concentration: 4020 nM
Compound 4: middle estimate off by 2.7-fold (0.43 log units), on the low side; the range from low to high includes it.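

In this assay, hydrogen in place of chloro on an aromatic carbon gives a 9.3-fold higher number from compound 1 to compound 4 (0.97 log units; beyond the scatter). The same change does not carry from one core to the other, either in direction or in size: the same change on two cores in this assay, a 2.1-fold lower number (0.31 log units; beyond the scatter) from compound 3 to compound 2 and a 9.3-fold higher number (0.97 log units; beyond the scatter) from compound 1 to compound 4, 19-fold (1.28 log units) apart, beyond the scatter of two such steps. These two steps do not separate the effect of the ring from that of the place of the chloro on it, and two cores give no rule for any further core.

Open, going by these compounds, is whether a bromo or a methyl in place of the chloro on the ring of compound 1 would keep the number of compound 1 or lose it as hydrogen does. Also open, on these data alone, is how a longer chain in place of the methyl on the shared core would act.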